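The compounds below may be only part of what the source reports. "The series", "measured", "known", "first", "only" and "open" are said of these compounds alone.

Measured compounds:
compound 1, `COc1ccc(N)c(C2=NN(C(C)=O)CC2)c1` — in an assay on isolated protein for inhibition of Nitric oxide synthase, inducible (Homo sapiens), with a stated time of 30 min, tested at 1 mM (a lower number here means less inhibition, a higher number more inhibition at the concentration tested (going by the name of the read-out)), compound 1 gives 20.4%
compound 2, `Nc1ccccc1C1=NN(C(=O)CCc2ccccc2)CC1` — in this assay compound 2 gives 5.64%

Compound 2 holds the lowest of the two numbers in this assay; its nearest neighbour is compound 1, whose value is higher by a margin beyond the usual scatter. Going by the values given here, no pair differing in one place has been measured, so no step is known, and the gap between compound 1 and compound 2 reflects more than one change.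

The next compound, compound 3, `CC(=O)N1CCC(c2ccccc2N)=N1`, follows from compound 2 by one change: hydrogen in place of benzyl on a saturated chain carbon bound to a carbonyl carbon. Compound 3 thus carries the same shortened acyl chain as compound 1 but lacks the methoxy group of compound 1.

The expected step from compound 2 to compound 3 in this assay is upward, of modest size, because compound 1 with the short chain gives 20.4% while compound 2 gives 5.64%; the step may not exceed the scatter. Compound 3 is estimated at 12%, within 0% to 28%, a rise of a number 6.4 percentage points higher from compound 2 to compound 3 (within the scatter) expected.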

Compound 3, a percentage reported as inhibition, at one concentration (the size of the read-out at that concentration, not a potency): 7.73%
Compound 3: the middle estimate sits 4.3 percentage points above what was measured, and the stated range covers the measured number.
By their numbers in this assay, from the lowest: compounds 2 and 3 (each within the scatter of the next); then compound 1.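

In this assay, the exchange of benzyl for hydrogen on a saturated chain carbon bound to a carbonyl carbon gives a number 2.1 percentage points higher from compound 2 to compound 3 (within the scatter), so this change on the acyl chain is not resolved from the scatter. Going by these compounds alone, the exchange of methoxy for hydrogen on an aromatic carbon gives a number 12.7 percentage points lower from compound 1 to compound 3 (beyond the scatter), which makes it the only one-place step so far that lies beyond the scatter and points to the aromatic carbon, rather than the chain position, as the place where the read-out responds. No accompanying measurement explains either step.

On these data alone, it remains open whether the methoxy step carries over to the benzyl-bearing chain of compound 2, since that step has been read only with the short acyl group of compound 3. Also open, as far as these compounds go, is how the read-out would respond to an ethoxy group, a hydroxyl group or a fluorine atom on that aromatic carbon, or to a longer unbranched alkyl chain in place of benzyl on the chain carbon.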